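Aryl Sulfone Exchange in a Metabotropic Glutamate Receptor 5 Series

The source may report more compounds than this note shows. Statements on the series, on what has been measured and on what is new or still open speak of the compounds shown alone.

Compound 1 `COc1ccc(S(=O)(=O)c2cnc3ccc(F)cc3c2N2CCC(C)CC2)cc1`: 85%
Compound 2 `CC1CCN(c2c(S(=O)(=O)c3ccc(F)c(Cl)c3)cnc3ccc(F)cc23)CC1`: 95%

In an assay on isolated protein for displacement of a labelled ligand from metabotropic glutamate receptor 5 (Homo sapiens), with a stated time of 60 min, tested at 1 uM (on this read-out lower numbers stand for less inhibition and higher numbers for more inhibition at the one concentration tested (going by the name of the read-out)), compound 2 gives 95%, the higher of the two numbers measured, yet the step of a number 10 percentage points higher from compound 1 to compound 2 (within the scatter) lies within the scatter, so compound 1 and compound 2 cannot be told apart. Compound 3 `Cc1ccc(S(=O)(=O)c2cnc3ccc(F)cc3c2N2CCC(C)CC2)cc1` differs from compound 2 by 4-methylphenyl in place of 3-chloro-4-fluorophenyl on a sulfonyl sulfur. Among the measured compounds shown here, the only measured step that bears on this change is a number 10 percentage points higher from compound 1 to compound 2 (within the scatter), another exchange of the aryl group on the sulfonyl sulfur, and it stayed within the scatter. No step beyond the scatter is therefore expected in this assay. Compound 3 is expected to give 88%, between 72% and 98%. This corresponds to an expected step of a number 7 percentage points lower from compound 2 to compound 3 (within the scatter).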

Compound 3, a percentage reported as inhibition, at one concentration (the size of the read-out at that concentration, not a potency): 91%
Compound 3: the middle estimate sits 3 percentage points below what was measured, and the stated range covers the measured number.
By their numbers in this assay, from the lowest: compounds 1, 3 and 2 (each within the scatter of the next).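

In this assay the second exchange on the sulfonyl sulfur gives a number 4 percentage points lower from compound 2 to compound 3 (within the scatter) and methyl in place of methoxy on an aromatic carbon gives a number 6 percentage points higher from compound 1 to compound 3 (within the scatter) as a further step. The 4-methoxyphenyl, 3-chloro-4-fluorophenyl and 4-methylphenyl groups at this position therefore cannot be told apart at the one concentration tested, and all three steps among them stay within the scatter. Nothing available explains this result. Still open, going by these compounds, is whether an amine or a carboxylic acid on this aromatic ring, or a longer chain in place of the methyl, would give a step beyond the scatter.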